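From 2-fluorophenyl to 2-methoxyphenyl

The source may hold more compounds than are shown below. What is called first, only, known or untested is meant among the compounds shown, and "the series" means these compounds.

Compound 1 `COc1cccc(N2CCN(c3c(CO)c(=O)oc4ccccc34)CC2)c1`: 38100 nM
Compound 2 `O=c1oc2ccccc2c(N2CCN(c3ccccc3)CC2)c1CO`: > 50000 nM (a limit, not a number)
Compound 3 `O=c1oc2ccccc2c(N2CCN(c3ccccc3F)CC2)c1CO`: > 50000 nM (a limit, not a number)

In a functional assay on WM1361 cells (Homo sapiens) for inhibition, read by MTT assay, with a stated time of 24 h (a higher number here means a weaker inhibitor, a lower number a stronger inhibitor), compound 3 gives only a limit, > 50000 nM. That is the limit of > 50000 nM in this assay, at which 2 of the 3 values shown sit.

Compound 4 `COc1ccccc1N1CCN(c2c(CO)c(=O)oc3ccccc23)CC1` has methoxy in place of fluoro on an aromatic carbon. Among the compounds with values here, no measured step makes exactly this change, so the nearest ones must serve. Within the data shown here, compound 1 is the only measured compound with a methoxy, and the only one with a number. Replacing its methoxy with hydrogen gives an at least 1.3-fold higher number from compound 1 to compound 2 (0.11 log units; that floor lies within the scatter). Swapping its 3-methoxyphenyl for 2-fluorophenyl gives an at least 1.3-fold higher number from compound 1 to compound 3 (0.11 log units; that floor lies within the scatter). Both sizes are only floors, so neither shows a real effect of the methoxy. Adding fluoro gives a step that the two limits leave unreadable from compound 2 to compound 3, which adds nothing further.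

Compound 4 carries 2-methoxyphenyl rather than 3-methoxyphenyl, which makes compound 1 at 38100 nM a loose guide. In this assay a small move to a lower number is expected, or none beyond the scatter, and a further limit is about as likely as a number. The expected step is an at least 1.1-fold lower number from compound 3 to compound 4 (0.07 log units; that floor lies within the scatter). Compound 4 is estimated at 42000 nM, with an expected range of 20000 nM to 60000 nM.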

Compound 4, half-maximal inhibitory concentration: > 50000 nM
Compound 4 was reported as a limit (the forecaster's own chance of this, stated with the estimate: 50%); middle value at least 1.1-fold (0.07 log units) from the limit.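

In this assay compound 4 gives a limit and not a number, so the steps to it from compound 2 and from compound 3 cannot be read, and methoxy in place of fluoro on this aromatic carbon, ortho to a large group, has no size that can be stated. Within the data shown here, the one readable comparison is of a new kind, since the methoxy stays and only its place changes: 2-methoxyphenyl in place of 3-methoxyphenyl gives an at least 1.3-fold higher number from compound 1 to compound 4 (0.11 log units; that floor lies within the scatter), a floor that shows no real effect of that move. Compound 1 is still the only compound with a number, and the other three all sit at one limit: the limit of > 50000 nM in this assay, at which 3 of the 4 values shown sit.

As far as these compounds go, whether compound 2, compound 3 and compound 4 truly differ from one another stays open, and so does whether compound 1 truly differs from any of them, since every floor lies within the scatter. Also open, from the compounds shown here alone, is how this aromatic ring would respond to an amine, a carboxylic acid or a longer chain such as ethoxy in the same place, and whether any of these would bring a value inside the range this assay can read.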